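The source may hold more compounds than are shown below. What is called first, only, known or untested is meant among the compounds shown, and "the series" means these compounds.

compound 1 `CCCCCC/C=C/C[C@H]1C[C@@H]([C@@H](O)c2ccccc2)CO[C@@H]1c1ccccc1` gives 4990 nM
compound 2 `C=CC[C@H]1C[C@@H]([C@@H](O)c2ccccc2)CO[C@@H]1c1ccccc1` gives 36000 nM
compound 3 `O=[N+]([O-])c1ccc(/C=C/C[C@H]2C[C@@H]([C@@H](O)c3ccccc3)CO[C@@H]2c2ccccc2)cc1` gives 4880 nM

These three compounds share a core and differ only in the end of one side chain. In a functional assay on HL-60 cells (Homo sapiens) for cytotoxicity, read by WST assay, with a stated time of 48 h (on this read-out higher numbers stand for weaker inhibition and lower numbers for stronger inhibition), compound 2 gives 36000 nM, the highest of the three numbers and so the weakest inhibition of the set.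

The next compound to be tested is compound 4 `O[C@@H](c1ccccc1)[C@H]1CO[C@H](c2ccccc2)[C@@H](C/C=C/C2CCCCC2)C1`. It differs from compound 2 by 2-cyclohexylethenyl in place of vinyl on a saturated chain carbon bound to a saturated ring carbon, which is 2-cyclohexylethenyl in place of vinyl on a saturated chain carbon bound to a saturated ring carbon.

Among the measured compounds shown here, two measured steps bear on this change. The closest removes the hexyl-bearing end of the chain, and it gives a 7.2-fold higher number from compound 1 to compound 2 (0.86 log units; beyond the scatter). Read backwards, that step suggests that building up the small end of compound 2 should lower the number. The second step compares two large ends, hexyl and 4-nitrophenyl, and it gives a 1.0-fold lower number from compound 1 to compound 3 (0.01 log units; within the scatter). For the measured compounds named here, the two large ends measured so far therefore read alike, although neither is a cyclohexyl ring, and no compound with such a ring has been measured yet.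

A drop of similar size is therefore expected, and the estimated step is a 6.5-fold lower number from compound 2 to compound 4 (0.82 log units; beyond the scatter). For compound 4 the expected value is 5500 nM, with an estimated range from 2000 nM to 15000 nM.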

Compound 4, half-maximal inhibitory concentration: 6260 nM
Estimate against measurement, compound 4: 1.1-fold (0.06 log units) below; the measured number falls inside the stated range.
By their numbers in this assay, from the lowest: compounds 3, 1 and 4 (each within the scatter of the next); then compound 2.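

In this assay, a third large chain end repeats the change seen from the small end of compound 2, this time with a six-membered non-aromatic ring of carbon only (a 5.8-fold lower number from compound 2 to compound 4 (0.76 log units; beyond the scatter)). That ring end reads alike with the two large ends already known, the aromatic 4-nitrophenyl (a 1.3-fold higher number from compound 3 to compound 4 (0.11 log units; within the scatter)) and the open-chain hexyl (a 1.3-fold higher number from compound 1 to compound 4 (0.10 log units; within the scatter)). At this place on the double-bonded chain carbon, these four compounds therefore separate vinyl from the three large ends but do not separate the large ends from one another, whether the end is a ring or a chain, aromatic or not.

Nothing measured in this set accounts for that pattern. Still open, on these data alone, is how short a chain end can be before the number climbs towards that of compound 2, as with an ethyl or butyl group, whether a longer chain such as decyl would lower the number further, and whether an end carrying an amine or a carboxylic acid would read like the three large ends.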